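Swapping the Fluorinated Aryl Group for a Methoxyphenyl

The source may report more compounds than this note shows. Statements on the series, on what has been measured and on what is new or still open speak of the compounds shown alone.

Compound 2 `CN(C)CCn1c(=O)c(=Cc2ccc(F)c(F)c2)s/c1=C1\C(=O)Nc2cc(F)ccc21` has the highest number of the three measured compounds in a functional assay on MDA-MB-231 cells (Homo sapiens) for inhibition, read by MTT assay, with a stated time of 72 h (on this read-out higher numbers stand for weaker inhibition and lower numbers for stronger inhibition), giving 25000 nM. Compound 3 `CCN(CC)CCCn1c(=O)c(=Cc2ccc(F)c(F)c2)s/c1=C1\C(=O)Nc2cc(F)ccc21` gives 2900 nM, and compound 1 `COc1cc(C=c2s/c(=C3\C(=O)Nc4ccc(F)cc43)n(CCN(C)C)c2=O)cc(OC)c1OC` gives 1900 nM. Compound 4 `COc1ccc(C=c2s/c(=C3\C(=O)Nc4cc(F)ccc43)n(CCN(C)C)c2=O)cc1` differs from compound 2 in one place: 4-methoxyphenyl in place of 3,4-difluorophenyl on a double-bonded chain carbon bound to an aromatic carbon. Within the data shown here, the only measured step, an 8.6-fold lower number from compound 2 to compound 3 (0.94 log units; beyond the scatter), concerns the amine on the chain rather than the aryl group, so it does not bear directly on this change. Compound 1 also carries a methoxy-bearing aryl group and has a clearly lower number than compound 2, but it differs from compound 2 in more than one place, so it is only a loose pointer. Compound 4 is therefore expected to show a lower number, a step of a 3.1-fold lower number from compound 2 to compound 4 (0.49 log units; beyond the scatter). The estimate for compound 4 is 8000 nM, with a range from 2000 nM to 30000 nM.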

Compound 4, half-maximal inhibitory concentration: 2090 nM
The estimate for compound 4 lay 3.8-fold (0.58 log units) above the measured number; low and high end bracket the measured number.
By their numbers in this assay, from the lowest: compounds 1, 4 and 3 (each within the scatter of the next); then compound 2.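

At the double-bonded chain carbon bound to an aromatic carbon, the choice of aryl group clearly matters: in this assay, 4-methoxyphenyl in place of 3,4-difluorophenyl gives a 12-fold lower number from compound 2 to compound 4 (1.08 log units; beyond the scatter). Among these compounds, the earlier single-place step concerned the amine on the chain, so this is the first direct reading of a change to the aryl group, and its size is substantial. No measurement here explains why this swap lowers the number.

From the compounds shown here alone, it remains open whether the lower number comes from gaining the methoxy group or from losing the two fluorines. An unsubstituted phenyl group at this place would help separate the two.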